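A few compounds are considered here, and "the series" means these few. Any claim that something is new, unique, unknown or untested is made for them only; others in the source may bear on it.

Measured compounds:
compound 1, `CCC(=O)N1CCN(Cc2nc3ccccc3n2Cc2cccc(C)c2)CC1`, with 85.1% in an assay on isolated protein for inhibition of aldehyde dehydrogenase 1A1 (Homo sapiens), read by spectrophotometry, tested at 10 uM; a lower number here means less inhibition, a higher number more inhibition at the concentration tested (going by the name of the read-out)
compound 2, `COc1ccc(C(=O)N2CCN(Cc3nc4ccccc4n3Cc3cccc(C)c3)CC2)cc1`, with 55.5% in this assay
compound 3, `Cc1cccc(Cn2c(CN3CCN(C(=O)C4CCCCC4)CC3)nc3ccccc32)c1`, with 31.9% in this assay

Compound 3 gives the lowest of the three numbers: one step reads a number 23.6 percentage points lower from compound 2 to compound 3 (beyond the scatter), and the other reads a number 53.2 percentage points lower from compound 1 to compound 3 (beyond the scatter), both beyond the scatter. The unmeasured compound 4, `Cc1cccc(Cn2c(CN3CCN(C(=O)c4ccc(C(F)(F)F)cc4)CC3)nc3ccccc32)c1`, differs from compound 3 in one place: 4-(trifluoromethyl)phenyl in place of cyclohexyl on a carbonyl carbon.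

The step that bears most directly on this change is the one in the other direction, from an aromatic group to cyclohexyl, which read a number 23.6 percentage points lower from compound 2 to compound 3 (beyond the scatter); the step from ethyl to cyclohexyl, a number 53.2 percentage points lower from compound 1 to compound 3 (beyond the scatter), points the same way. Returning from cyclohexyl to a six-membered aromatic ring is therefore expected to raise inhibition by a modest step, roughly a number 18.1 percentage points higher from compound 3 to compound 4 (beyond the scatter), though the trifluoromethyl group has no measured precedent here. For compound 4 the expected value in this assay is 50%, within a range from 25% to 75%.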

Compound 4, a percentage reported as inhibition, at one concentration (the size of the read-out at that concentration, not a potency): 22.9%
The estimate for compound 4 lay 27.1 percentage points above the measured number; the measured number lies below the stated range.
By their numbers in this assay, from the lowest: compounds 4 and 3 (each within the scatter of the next); then compound 2; then compound 1.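

In this assay, an aromatic ring on the carbonyl carbon does not by itself preserve inhibition: the swap of cyclohexyl for 4-(trifluoromethyl)phenyl reads a number 9 percentage points lower from compound 3 to compound 4 (within the scatter) and leaves these two groups indistinguishable in this measurement. What is attached to that ring matters, as the change of methoxy to trifluoromethyl on an aromatic carbon reads a number 32.6 percentage points lower from compound 2 to compound 4 (beyond the scatter) with the rest of the molecule unchanged. Ethyl keeps its lead over this aromatic group as well, with a number 62.2 percentage points lower from compound 1 to compound 4 (beyond the scatter) as the step, so compound 1 stands above all three others.

Nothing shown explains these differences.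
Still open, from the compounds shown here alone, is whether a propyl chain on the carbonyl carbon would hold up as ethyl does, and whether an unsubstituted phenyl ring, or one carrying an amine, would fall nearer compound 2 or compound 4.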